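A few compounds are considered here, and "the series" means these few. Any claim that something is new, unique, unknown or untested is made for them only; others in the source may bear on it.

Measured compounds:
compound 1, `COc1nc2ccc(Br)cc2cc1C(c1ccccc1)n1cc(-c2ccccc2)nn1`, 5.97%
compound 2, `COc1nc2ccc(Br)cc2cc1C(c1ccccc1)n1cc(CCCO)nn1`, 14.7%
compound 3, `CCCc1cn(C(c2ccccc2)c2cc3cc(Br)ccc3nc2OC)nn1`, 8.3%

In an ADME assay on PC-3 cells (Homo sapiens) for cytotoxicity, read by sulforhodamine B assay, with a stated time of 48 h, tested at 10 uM (on this read-out lower numbers stand for less inhibition and higher numbers for more inhibition at the one concentration tested (going by the name of the read-out)), compound 3 stands second highest of the three numbers; its nearest neighbour is compound 1, a number 2.3 percentage points higher from compound 1 to compound 3 (within the scatter), and its furthest is compound 2, a number 6.4 percentage points lower from compound 2 to compound 3 (within the scatter). The unmeasured compound 4, `COc1nc2ccc(Br)cc2cc1C(c1ccccc1)n1cc(-c2ccccc2C(F)(F)F)nn1`, differs from compound 3 by 2-(trifluoromethyl)phenyl in place of propyl on an aromatic carbon. Going by the values given here, the step that bears on this change is the one from compound 1 to compound 3, where propyl replaced phenyl on the same aromatic carbon: a number 2.3 percentage points higher from compound 1 to compound 3 (within the scatter). Compound 4 carries an aryl group again, so the account expects a change of about a number 1.3 percentage points lower from compound 3 to compound 4 (within the scatter), none beyond the scatter. For compound 4 the estimate in this assay is 7%, with a range from 0% to 18%.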

Compound 4, a percentage reported as inhibition, at one concentration (the size of the read-out at that concentration, not a potency): 17.4%
For compound 4 the middle estimate is 10.4 percentage points below the measured one; measured number inside the range.
By their numbers in this assay, from the lowest: compounds 1, 3, 2 and 4 (each within the scatter of the next, the first and the last beyond it).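

In this assay, putting trifluoromethyl on the phenyl group at this aromatic carbon gives a number 11.4 percentage points higher from compound 1 to compound 4 (beyond the scatter) and is the only step among these compounds to pass the scatter, though modestly. Against the chains, the steps of a number 9.1 percentage points higher from compound 3 to compound 4 (within the scatter) and a number 2.7 percentage points higher from compound 2 to compound 4 (within the scatter) leave 2-(trifluoromethyl)phenyl not separable from propyl or 3-hydroxypropyl. On these data alone, whether a methoxy group, an amine or a carboxylic acid in place of the trifluoromethyl would hold this level stays open. Nothing measured here accounts for the step from the plain phenyl group.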